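The compounds below may be only part of what the source reports. "The series", "measured", "known", "first", "only" and "open" are said of these compounds alone.

Compound 3 `COc1ccc(-c2cn(C[C@H](O)[C@H]3OC(=O)C(OCc4ccccc4)=C3OCc3ccccc3)nn2)cc1` is one of three analogues that share a core and differ only in the group on the triazole carbon. In a functional assay on SW-620 cells (Homo sapiens) for antiproliferative activity, read by MTT assay, with a stated time of 72 h (on this read-out lower numbers stand for stronger inhibition and higher numbers for weaker inhibition), compound 3 gives 58200 nM. Of the two numbers shown, compound 3 sits alongside compound 1 `Cc1ccc(S(=O)(=O)NCc2cn(C[C@H](O)[C@H]3OC(=O)C(OCc4ccccc4)=C3OCc3ccccc3)nn2)cc1`, which in this assay gives 45800 nM, so that the pair is separated by a 1.3-fold higher number from compound 1 to compound 3 (0.10 log units; within the scatter). Compound 2 `O=C1O[C@H]([C@@H](O)Cn2cc(-c3cc(F)cc(F)c3)nn2)C(OCc2ccccc2)=C1OCc1ccccc1` returns in this assay only a limit, > 100000 nM, which is the limit of > 100000 nM in this assay, at which 1 of the 3 values shown sits. Against that limit the other two read as an at least 2.1-fold higher number from compound 1 to compound 2 (0.33 log units; beyond the scatter) and an at least 1.7-fold lower number from compound 2 to compound 3 (0.23 log units; that floor lies within the scatter).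

Compound 4 `Cc1ccc(-c2cn(C[C@H](O)[C@H]3OC(=O)C(OCc4ccccc4)=C3OCc3ccccc3)nn2)cc1` differs from compound 3 by methyl in place of methoxy on an aromatic carbon. Among the measured compounds shown here, none of the measured steps touches this change directly: each of them swaps the whole group on the triazole carbon, whereas here the ring is kept and only its para substituent is exchanged. For the measured compounds named here, the one step between two six-membered aromatic rings, an at least 1.7-fold lower number from compound 2 to compound 3 (0.23 log units; that floor lies within the scatter), stays within the scatter, and the step of a 1.3-fold higher number from compound 1 to compound 3 (0.10 log units; within the scatter) does too. Compound 4 is therefore expected to give a number close to that of compound 3, with a step of a 1.0-fold higher number from compound 3 to compound 4 (0.01 log units; within the scatter). The estimate for compound 4 in this assay is 60000 nM, within a range from 30000 nM to 100000 nM.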

Compound 4, half-maximal inhibitory concentration: > 100000 nM
Compound 4: a limit, no number; the forecaster's own chance of this, stated with the estimate: 20%; middle value at least 1.6-fold (0.22 log units) away from the limit.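

The reading for compound 4 in this assay is a limit and not a number, and compound 2 stands at the same limit: the limit of > 100000 nM in this assay, at which 2 of the 4 values shown sit. Keeping the ring and exchanging only methoxy for methyl, a swap that takes away one oxygen and one hydrogen-bond acceptor, gives an at least 1.7-fold higher number from compound 3 to compound 4 (0.23 log units; that floor lies within the scatter), so this single change does not establish a real loss, although the methyl compound no longer returns a number. The wider exchange of the (((4-methylphenyl)sulfonyl)amino)methyl group for 4-methylphenyl gives an at least 2.1-fold higher number from compound 1 to compound 4 (0.33 log units; beyond the scatter), which shows that a phenyl ring on the triazole carbon can, with the methyl substituent as with the two fluorines of compound 2, fall short of the activity of compound 1.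

On these data alone, the step from compound 2 to compound 4 cannot be read, as both values are limits, and how far compound 4 truly lies from compound 3 stays open. Also open, as far as these compounds go, is whether an amine, a hydroxyl or a longer chain such as ethoxy in place of methoxy would return a number in this assay.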